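Nitrooxy Added to the Methyl of Compound 3

This account rests on a few compounds, and the source may have more. Where it says the series, first, only, none or still open, it means among the compounds named here.

Compound 3 `CC(=O)Nc1ccc(S(=O)(=O)Nn2c(C)nc3ccccc3c2=O)cc1` stands highest of the three numbers in a functional assay on the whole organism (strain Sprague-Dawley) for inhibition, with Rattus norvegicus as the target, read by paw edema, with stated times of 30 min and 2 h, at a dose of 80 mg/kg by the oral route; on this read-out higher numbers stand for more inhibition at the one dose given (going by the name of the read-out) and lower numbers for less inhibition: compound 3 gives 37.4%, compound 2 `Cc1ccc(S(=O)(=O)Nn2c(CO[N+](=O)[O-])nc3ccccc3c2=O)cc1` gives 15.7% and compound 1 `O=c1c2ccccc2nc(CO[N+](=O)[O-])n1NS(=O)(=O)c1ccccc1` gives 11.6%, both beyond the scatter from compound 3. Among the measured compounds shown here, the only measured step, a number 4.1 percentage points higher from compound 1 to compound 2 (within the scatter), concerns a methyl on an aromatic carbon and does not bear on the change at hand. Compound 4 `CC(=O)Nc1ccc(S(=O)(=O)Nn2c(CO[N+](=O)[O-])nc3ccccc3c2=O)cc1` differs from compound 3 as follows: nitrooxy in place of hydrogen on a saturated chain carbon bound to an aromatic carbon. For the measured compounds named here, no measured pair isolates this nitrooxy change, so the direction is uncertain; compounds 1 and 2 carry the nitrooxy group but differ elsewhere too. A modest downward step is therefore expected, a number 9.4 percentage points lower from compound 3 to compound 4 (within the scatter), and for compound 4 in this assay the estimate is 28%, between 12% and 44%.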

Compound 4, a percentage reported as inhibition, in the whole organism at one dose (the size of the read-out at that dose, not a potency): 40.4%
For compound 4 the middle estimate is 12.4 percentage points below the measured one, within the range that was stated.
By their numbers in this assay, from the lowest: compounds 1 and 2 (each within the scatter of the next); then compounds 3 and 4 (each within the scatter of the next).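

In this assay, among the compounds shown here, the nitrooxy change on this saturated chain carbon stands alone for the first time, and it reads as a number 3 percentage points higher from compound 3 to compound 4 (within the scatter) with no effect established. With the nitrooxy group kept, acetamido in place of methyl on an aromatic carbon gives a number 24.7 percentage points higher from compound 2 to compound 4 (beyond the scatter) and acetamido in place of hydrogen gives a number 28.8 percentage points higher from compound 1 to compound 4 (beyond the scatter) so the steps beyond the scatter lie at the aromatic carbon and not at the chain carbon. From the compounds shown here alone, whether an amine or a carboxylic acid on that chain carbon would also leave the read-out within the scatter stays open. Nothing at hand explains any of these steps.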